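A Methoxy Step from Compound 3 to Compound 4

The source may hold more compounds than are shown below. What is called first, only, known or untested is meant among the compounds shown, and "the series" means these compounds.

Three close relatives of a shared core have been tested in an ADME assay on L02 cells (Homo sapiens) for cytotoxicity, read by MTT assay, with a stated time of 48 h; on this read-out higher numbers stand for weaker inhibition and lower numbers for stronger inhibition. Compound 1 `Cc1ccc2[nH]c(=O)c(-c3nc4ccccc4[nH]3)cc2c1` reaches only the limit of the assay, and so in this assay compound 1 gives > 100000 nM, a limit rather than a number. Compound 2 `Cc1ccc2[nH]c(=O)c(-c3nc4cc(Cl)ccc4[nH]3)cc2c1` carries chloro in place of hydrogen on an aromatic carbon; in this assay compound 2 gives > 100000 nM, again a limit. Compound 3 `Cc1cc2nc(-c3cc4ccccc4[nH]c3=O)[nH]c2cc1C` also stops at the limit, and in this assay compound 3 gives > 100000 nM. That puts compound 3 at the limit of > 100000 nM in this assay, at which 3 of the 3 values shown sit, with no number of its own to set against the other two.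

Compound 4 `COc1ccc2[nH]c(=O)c(-c3nc4cc(C)c(C)cc4[nH]3)cc2c1` differs from compound 3 by methoxy in place of hydrogen on an aromatic carbon. Among the compounds with values here, the one measured step, a step that the two limits leave unreadable from compound 1 to compound 2, cannot be sized: both of its ends are limits. So no measured step tells how methoxy in place of hydrogen on an aromatic carbon shifts this assay. Within the data shown here, with every value so far at the limit, compound 4 is expected to stay there too, the expected step that the limit leaves unreadable from compound 3 to compound 4 being none beyond the scatter. The estimate for compound 4 is 150000 nM, with a range from 60000 nM to 500000 nM.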

Compound 4, half-maximal inhibitory concentration: > 100000 nM
Compound 4: only a limit was reported; the forecaster's own chance of this, stated with the estimate: 85%; the middle value does not contradict the limit.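

Compound 4 also stops at a limit, just as compound 3 does, so no new step can be read from the pair in this assay: the limit of > 100000 nM in this assay, at which 4 of the 4 values shown sit. The compounds shown leave open whether any change on the shared core would give a measured number rather than a limit, and which groups would shift the read-out at all.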